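The compounds below may be only part of what the source reports. "The series", "measured", "known", "first", "only" and "open" are said of these compounds alone.

Two compounds have a number so far in a functional assay on L1210 cells (Mus musculus) for antiproliferative activity, read by MTT assay, with a stated time of 72 h (a higher number here means a weaker inhibitor, a lower number a stronger inhibitor), as follows:

- compound 1 `COc1ccc(C2OC(c3cc(OC)c(OC)c(OC)c3)=NN2C(C)=O)cc1OC(C)=O` gives 3900 nM
- compound 2 `COc1ccc(C2=NN(C(C)=O)C(c3cccc([N+](=O)[O-])c3)O2)cc1` gives 47000 nM

Compound 2 holds the higher number of the two, which makes it the weaker inhibitor of the pair, and the gap to compound 1 lies beyond the usual scatter. The two differ in several places, so that gap cannot be tied to any single group.

Still unmeasured is compound 3 `COc1ccc(C2=NN(C(C)=O)C(c3cccc(Br)c3)O2)cc1` which keeps the rest of compound 2 and carries bromo in place of nitro on an aromatic carbon of a six-membered aromatic ring of carbon only, meta to a large group (bromo in place of nitro on an aromatic carbon). Among the measured compounds shown here, no measured pair shows this exchange, so the expectation rests on little. Compound 2 sits high at 47000 nM and compound 1 reaches 3900 nM on a different substitution, which leaves room downward. A moderate move toward a lower number in this assay is therefore expected, though it may stay close to the scatter. The expected change is an estimated 2.4-fold lower number from compound 2 to compound 3 (0.37 log units; beyond the scatter) in size. For compound 3 the estimated value is 20000 nM with an expected range from 7000 nM to 50000 nM in all.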

Compound 3, half-maximal inhibitory concentration: 37000 nM
For compound 3 the middle estimate is 1.9-fold (0.27 log units) below the measured one, and the stated range covers the measured number.
By their numbers in this assay, from the lowest: compound 1; then compounds 3 and 2 (each within the scatter of the next).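

In this assay, among the compounds shown here, the exchange on an aromatic carbon of a six-membered aromatic ring of carbon only, meta to a large group, gives a 1.3-fold lower number from compound 2 to compound 3 (0.10 log units; within the scatter), the first comparison here that isolates a single place. Nitro, with its 3 heavy atoms and 2 hydrogen-bond acceptors, gives way to bromo, with 1 heavy atom and 0 hydrogen-bond acceptors, and the two compounds still cannot be told apart in this assay, so at this position the read-out does not separate these two quite different groups. No accompanying measurement bears on this result.

For the compounds shown here, whether an amine or a carboxylic acid at this same position would shift the number beyond the scatter remains open, since nitro and bromo are the only two groups compared here. Also open, as far as these compounds go, is whether this exchange would read the same on the core of compound 1, whose several differences from compound 2 still cannot be tied to any single group.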